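A Third Fluoro on a Series Held at a Limit

The source may hold more compounds than are shown below. What is called first, only, known or untested is meant among the compounds shown, and "the series" means these compounds.

In a functional assay on MCF cells (Homo sapiens) for antiproliferative activity, with a stated time of 72 h (on this read-out lower numbers stand for stronger inhibition and higher numbers for weaker inhibition), compound 1 (`OC[C@H]1O[C@@H](n2cnc3c(NCc4ccccc4F)ncnc32)[C@H](O)[C@@H]1O`) gives > 166000 nM, which is a limit and not a number. Compound 2 (`OC[C@H]1O[C@@H](n2cnc3c(NCc4ccc(Br)cc4)ncnc32)[C@H](O)[C@@H]1O`) gives > 166000 nM, also a limit. Compound 3 (`OC[C@H]1O[C@@H](n2cnc3c(NCc4ccc(F)cc4F)ncnc32)[C@H](O)[C@@H]1O`) gives > 166000 nM, again a limit, so it offers no exact starting number. The whole picture so far is the limit of > 166000 nM in this assay, at which 3 of the 3 values shown sit.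

Compound 4 (`OC[C@H]1O[C@@H](n2cnc3c(NCc4ccc(F)c(F)c4F)ncnc32)[C@H](O)[C@@H]1O`) changes compound 3 in one place: fluoro in place of hydrogen on an aromatic carbon. The group goes from 2,4-difluorophenyl to 2,3,4-trifluorophenyl, and the new fluoro sits ortho to two fluoro groups.

For the measured compounds named here, the closest precedent is a step that the two limits leave unreadable from compound 1 to compound 3, the same exchange of fluoro in place of hydrogen on an aromatic carbon. The other two measured steps are a step that the two limits leave unreadable from compound 1 to compound 2 and a step that the two limits leave unreadable from compound 2 to compound 3. Each of the three has a limit at both ends, so none has a size that can be carried over. With no readable step to build on, no shift in either direction can be predicted, and compound 4 is expected to stay at the same limit in this assay. The expected step is a step that the limit leaves unreadable from compound 3 to compound 4.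

Compound 4 is estimated at 180000 nM, with an expected range of 70000 nM to 400000 nM, and it will most likely be reported only as a limit.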

Compound 4, half-maximal inhibitory concentration: > 166000 nM
Compound 4 was reported as a limit (the forecaster's own chance of this, stated with the estimate: 85%); the middle value does not contradict the limit.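

In this assay compound 4 gives > 166000 nM, which is a limit and not a number. Its steps from compound 1, compound 2 and compound 3 cannot be read, since each has a limit at both ends. The compounds shown leave open whether changing the groups on the phenyl ring alters activity at all, with every result resting on one limit: the limit of > 166000 nM in this assay, at which 4 of the 4 values shown sit.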